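This account rests on a few compounds, and the source may have more. Where it says the series, first, only, none or still open, it means among the compounds named here.

In an assay on CHO cells for displacement of a labelled ligand from adenosine receptor A3 (Homo sapiens), read by scintillation counting, with a stated time of 3 h (a higher number here means a weaker inhibitor, a lower number a stronger inhibitor), two compounds have been measured. Compound 1 `Cn1cc2c(Cl)nc(NC(=O)c3ccccc3)nc2n1` gives 23600 nM, and compound 2 `CC(C)n1cc2c(Cl)nc(NC(=O)c3ccccc3)nc2n1` gives 12800 nM. Going by the values given here, the single step between them, a 1.8-fold lower number from compound 1 to compound 2 (0.27 log units; within the scatter), comes from isopropyl in place of methyl on an aromatic nitrogen. On these two numbers compound 2 stands lowest, with compound 1 nearest to it and within the scatter, so neither can be called the stronger inhibitor.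

Compound 3 `CC(C)n1cc2c(Cl)nc(NC(=O)c3ccc(C(F)(F)F)cc3)nc2n1` differs from compound 2 by trifluoromethyl in place of hydrogen on an aromatic carbon of a six-membered aromatic ring of carbon only, para to a large group. Among the compounds with values here, no measured step bears on this change: the one step known, from compound 1 to compound 2, concerns the aromatic nitrogen and not the carbon ring, and it stayed within the scatter in this assay. With nothing to point in either direction, the step expected is a 1.3-fold lower number from compound 2 to compound 3 (0.11 log units; within the scatter), none beyond the scatter. The estimate for compound 3 in this assay is 10000 nM, with a range from 3000 nM to 40000 nM.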

Compound 3, inhibition constant: 10300 nM
Estimate against measurement, compound 3: 1.0-fold (0.01 log units) below; measured number inside the range.
By their numbers in this assay, from the lowest: compounds 3, 2 and 1 (each within the scatter of the next, the first and the last beyond it).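

In this assay, trifluoromethyl in place of hydrogen on an aromatic carbon, para to a large group, gives a 1.2-fold lower number from compound 2 to compound 3 (0.09 log units; within the scatter), so the first change shown on this six-membered aromatic ring of carbon only stays within the scatter, just as the earlier change on the aromatic nitrogen did with a 1.8-fold lower number from compound 1 to compound 2 (0.27 log units; within the scatter). Four heavy atoms enter here where only a hydrogen stood, yet compound 3 at 10300 nM cannot be told apart from compound 2 at 12800 nM, so this position takes trifluoromethyl with no change beyond the scatter. No measurement at hand says what lies behind this result.

A single group at a single place leaves open whether another group there, such as an amine, a carboxylic acid or a methoxy group, would shift the number beyond the scatter, and whether trifluoromethyl would do so on another carbon of the same ring. Going by these compounds, all three compounds also carry the same chlorine on the shared core, so the effect of an amine or a longer chain in its place remains open as well.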